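A few compounds are considered here, and "the series" means these few. Any claim that something is new, unique, unknown or untested is made for them only; others in the source may bear on it.

Three compounds have been measured in an assay on MDA-MB-231 cells for binding affinity to C-X-C chemokine receptor type 4 (Homo sapiens), read by microscopy, with stated times of 10 min and 30 min; on this read-out higher numbers stand for an effect only at larger amounts of compound and lower numbers for an effect already at smaller amounts:

Compound 1 `Cc1cccc(S(=O)(=O)NCc2ccc(CNC(=O)c3ccc(CNc4ncccn4)cc3)cc2)c1` gives 100 nM.
Compound 2 `O=C(NCc1ccc(CNS(=O)(=O)c2ccc3c(c2)CCO3)cc1)c1ccc(CNc2ncccn2)cc1` gives 1000 nM.
Compound 3 `O=C(NCc1ccc(CNS(=O)(=O)c2ccccc2F)cc1)c1ccc(CNc2ncccn2)cc1` gives 1000 nM.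

All three share the same core and differ only in the group on the sulfonyl sulfur. Compound 3 stands level with compound 2 at the digits shown, and the two together carry the highest numbers of the set; the only step away from compound 3 that lies beyond the scatter is a 10-fold higher number from compound 1 to compound 3 (1.00 log units; beyond the scatter), a modest change, matched in size by a 10-fold higher number from compound 1 to compound 2 (1.00 log units; beyond the scatter). Between compound 2 and compound 3 the step is no change at the digits printed from compound 2 to compound 3 (within the scatter).

Compound 4 `O=C(NCc1ccc(CNS(=O)(=O)c2ccc(F)c(F)c2)cc1)c1ccc(CNc2ncccn2)cc1` is the next compound, not yet measured. It differs from compound 3 in one place: 3,4-difluorophenyl in place of 2-fluorophenyl on a sulfonyl sulfur. Within the data shown here, none of the measured steps moves a fluorine or adds a second one, so they give no direct guide; they show only that a 2-fluorophenyl and a larger bicyclic group land at the same number while 3-methylphenyl sits lower. In this assay compound 4 is therefore expected to stay near compound 3, with a step of a 1.3-fold lower number from compound 3 to compound 4 (0.10 log units; within the scatter) that is not expected to exceed the scatter. The estimate for compound 4 is 800 nM, with a range from 250 nM to 3000 nM.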

Compound 4, effective concentration (reported as EC, without a stated level of effect): 100 nM
For compound 4 the middle estimate is 8.0-fold (0.90 log units) above the measured one; measured number below the stated range.
By their numbers in this assay, from the lowest: compounds 1 and 4 (each within the scatter of the next); then compounds 2 and 3 (each within the scatter of the next).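

In this assay, the group on the sulfonyl sulfur can shift the number even when both groups carry fluorine: a 10-fold lower number from compound 3 to compound 4 (1.00 log units; beyond the scatter), so the presence of fluorine alone does not set the result. The 3,4-difluorophenyl group also separates from the larger group of compound 2, with a 10-fold lower number from compound 2 to compound 4 (1.00 log units; beyond the scatter), yet it matches the 3-methylphenyl group, with no change at the digits printed from compound 1 to compound 4 (within the scatter), which shows that two quite different groups on this sulfur can give the same reading. Nothing measured explains these differences.

This change both removes the 2-fluorophenyl arrangement and adds a second fluorine, and the compounds shown cannot separate those two parts. As far as these compounds go, it also remains open how a plain phenyl or an alkyl chain on the sulfonyl sulfur would compare.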